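Tail aryl group exchange, compound 2 to compound 3

A few compounds are considered here, and "the series" means these few. Any claim that something is new, unique, unknown or untested is made for them only; others in the source may bear on it.

Among the measured compounds shown here, compound 2 `Cc1c(CCCC(=O)O)c2cccc(/C=C/c3ccc(OCCCCc4c(F)cc(F)c(F)c4F)cc3)c2n1CC(=O)O` is one of two compounds measured so far in a functional assay on CHO-K1 cells for antagonist activity at cysteinyl leukotriene receptor 1 (Homo sapiens), read by fluorescence and calcium flux, with stated times of 30 min and 1 h (a higher number here means a weaker inhibitor, a lower number a stronger inhibitor), where compound 2 gives 1.6 nM. For the measured compounds named here, its only neighbour is compound 1 `Cc1c(CCCC(=O)O)c2cccc(/C=C/c3ccc(OCCCCc4c(F)c(F)cc(F)c4F)cc3)c2n1CC(=O)O`, which in this assay gives 2.2 nM; the step of a 1.4-fold lower number from compound 1 to compound 2 (0.14 log units; within the scatter) separates the two, so neither can be placed above the other on these numbers. Compound 3 `Cc1c(F)cccc1CCCCOc1ccc(/C=C/c2cccc3c(CCCC(=O)O)c(C)n(CC(=O)O)c23)cc1` has not yet been measured. Relative to compound 2 the change is 3-fluoro-2-methylphenyl in place of 2,3,4,6-tetrafluorophenyl on a saturated chain carbon, four bonds along the chain from an oxygen on an aromatic ring. Going by the values given here, the single measured step bears only loosely on this move: it exchanged one tetrafluorophenyl for another at the same place, and a 1.4-fold lower number from compound 1 to compound 2 (0.14 log units; within the scatter) stayed within the scatter, giving no sign that the fluorine arrangement there shifts the read-out. Trading four fluorines for one fluorine and a methyl is a different kind of change, for which no measured step exists. The expectation is accordingly a step of a 2.2-fold higher number from compound 2 to compound 3 (0.34 log units; beyond the scatter) in this assay, leaning toward a weaker inhibitor but with wide uncertainty. For compound 3 the estimated value in this assay is 3.5 nM, within the range 1 nM to 12 nM.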

Compound 3, half-maximal inhibitory concentration: 1.1 nM
The estimate for compound 3 lay 3.2-fold (0.50 log units) above the measured number; the range from low to high includes it.
By their numbers in this assay, from the lowest: compounds 3, 2 and 1 (each within the scatter of the next).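

In this assay the tail aryl group was until now seen only as two tetrafluorophenyl isomers, whereas 3-fluoro-2-methylphenyl, on a saturated chain carbon four bonds along the chain from an oxygen on an aromatic ring, is a different kind of group, and the exchange gives a 1.5-fold lower number from compound 2 to compound 3 (0.16 log units; within the scatter) when it replaces 2,3,4,6-tetrafluorophenyl and a 2.0-fold lower number from compound 1 to compound 3 (0.30 log units; within the scatter) when it replaces 2,3,5,6-tetrafluorophenyl. Across these three compounds, then, the read-out stays within the scatter even though the group goes from four fluorines to one fluorine and a methyl, and from 10 heavy atoms to 8, so at this position the full tetrafluoro pattern is not needed to keep the number in this range. No measurement of any property of these groups accompanies the numbers, so nothing here accounts for the result.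

The compounds shown leave open how much the methyl and the single fluorine each contribute, which 2-methylphenyl, 3-fluorophenyl or plain phenyl would separate. They also leave open whether this insensitivity holds for a charged or hydrogen-bonding substituent on the same ring, such as an amine or a carboxylic acid.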